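Moving the fluorine on compound 3

The compounds below may be only part of what the source reports. "The series", "measured", "known", "first", "only" and "open" are said of these compounds alone.

Three compounds have been measured so far in a physicochemical assay for lipophilicity, read by HPLC (on this read-out lower numbers stand for lower lipophilicity and higher numbers for higher lipophilicity), and read as follows

- compound 1 `Nc1ccccc1NC(=O)c1ccc(CNC2=N[C@@H](c3ccccc3)CN2)cc1` gives 1.92
- compound 2 `Nc1ccccc1NC(=O)c1ccc(CSC2=N[C@@H](Cc3ccccc3)CO2)cc1` gives 5.41
- compound 3 `Nc1ccccc1NC(=O)c1ccc(CNC2=NC(c3ccc(F)cc3)CO2)cc1` gives 3.39

Compound 3 stands second highest of the three. Compound 1 lies below it and compound 2 lies above it, and both gaps are beyond the usual scatter. These three compounds differ from one another in more than one place, so none of the gaps isolates a single structural change.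

Compound 4 `Nc1ccccc1NC(=O)c1ccc(CNC2=NC(c3cccc(F)c3)CO2)cc1` has not yet been measured. It carries 3-fluorophenyl in place of 4-fluorophenyl on a saturated ring carbon, next to the ring nitrogen, and the change is 3-fluorophenyl in place of 4-fluorophenyl on a saturated ring carbon with the same atoms joined differently. Among the compounds with values here, no measured pair shows what such a change does in this assay and so the only anchor is compound 3 at 3.39 as the starting point. No step beyond the scatter is expected, in either direction. The expected change is a number 0.01 log units higher from compound 3 to compound 4 (within the scatter) and it is an estimate, not a measurement. For compound 4 the estimated value is 3.4 with an expected range of 3.05 to 3.75 once the measurement is made.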

Compound 4, distribution coefficient: 3.42
Estimate against measurement, compound 4: 0.02 log units below; measured number inside the range.
By their numbers in this assay, from the lowest: compound 1; then compounds 3 and 4 (each within the scatter of the next); then compound 2.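

In this assay, within the data shown here, the exchange of 3-fluorophenyl in place of 4-fluorophenyl on a saturated ring carbon, next to the ring nitrogen, comes out as a number 0.03 log units higher from compound 3 to compound 4 (within the scatter) and is the first step here that isolates a single structural change, which the three earlier compounds, differing in more than one place, could not offer. On this core and at this position, then, the two fluorophenyl groups, which have the same atoms joined differently, cannot be told apart on this read-out, so the place of the fluorine on that phenyl ring leaves no mark that can be read here. Nothing at hand bears on why the two read alike.

This single pair says nothing of what a chlorine, a methoxy group or a carboxylic acid would do on that phenyl ring in place of the fluorine. On these data alone, whether the same exchange would read the same way on the core of compound 1 or of compound 2 also remains open.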